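The compounds below may be only part of what the source reports. "The series", "measured", "known", "first", "only" and "open" are said of these compounds alone.

The measured compounds:
- Compound 1 `COc1ccc(/C=C\C(=O)O)c(OCc2cn(-c3ccccc3I)nn2)c1CC=C(C)C` gives 23100 nM in a functional assay on HCT-116 cells (Homo sapiens) for cytotoxicity, read by MTT assay, with a stated time of 24 h; a higher number here means a weaker inhibitor, a lower number a stronger inhibitor.
- Compound 2 `COc1ccc(/C=C\C(=O)O)c(OCc2cn(-c3cccc([N+](=O)[O-])c3)nn2)c1CC=C(C)C` gives 27300 nM.
- Compound 3 `COc1ccc(/C=C\C(=O)O)c(OCc2cn(-c3ccccc3C#N)nn2)c1CC=C(C)C` gives 38300 nM.

Compound 3 has the highest of the three numbers, yet its gaps to compound 2 and to compound 1 both lie within the scatter of repeated measurements, so nothing here separates the three. Compound 4 `COc1ccc(/C=C\C(=O)O)c(OCc2cn(-c3cccc(C#N)c3)nn2)c1CC=C(C)C` has not been measured. It differs from compound 3 in one place: 3-cyanophenyl in place of 2-cyanophenyl on an aromatic nitrogen. The earlier steps shown here that bear on this are the ones that exchanged the group on the aromatic nitrogen, a 1.2-fold higher number from compound 1 to compound 2 (0.07 log units; within the scatter) and a 1.4-fold higher number from compound 2 to compound 3 (0.15 log units; within the scatter), and the step of a 1.7-fold higher number from compound 1 to compound 3 (0.22 log units; within the scatter), which exchanged one small group for another on that aromatic ring. None of these moved the number beyond the scatter, and the present change keeps the same atoms and only joins them differently, so the expectation for compound 4 is a step of a 1.2-fold lower number from compound 3 to compound 4 (0.08 log units; within the scatter), with no change beyond the scatter. Compound 4 is therefore expected to give about 32000 nM, within a range from 15000 nM to 65000 nM.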

Compound 4, half-maximal inhibitory concentration: 35300 nM
For compound 4 the middle estimate is 1.1-fold (0.04 log units) below the measured one, within the range that was stated.
By their numbers in this assay, from the lowest: compounds 1, 2, 4 and 3 (each within the scatter of the next).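

Among these compounds, compound 4 gives the first comparison here in which the nitrile stays and only its place changes, from 2-cyanophenyl to 3-cyanophenyl, and in this assay this gives a 1.1-fold lower number from compound 3 to compound 4 (0.04 log units; within the scatter). The 3-cyanophenyl group also stays within the scatter when set against the 3-nitrophenyl group, a 1.3-fold higher number from compound 2 to compound 4 (0.11 log units; within the scatter), and against the 2-iodophenyl group, a 1.5-fold higher number from compound 1 to compound 4 (0.18 log units; within the scatter), so among these four compounds neither the choice of these groups nor this shift of the nitrile separates the numbers. No other measurement is available to explain these results.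

The compounds shown leave open whether an amine or a hydroxyl group on this phenyl ring would move the number beyond the scatter. They also leave open what a longer alkyl chain in place of the phenyl ring on the aromatic nitrogen would do.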